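Chloro to bromo on compound 1: working notes

The source may hold more compounds than are shown below. What is called first, only, known or untested is meant among the compounds shown, and "the series" means these compounds.

Measured in a functional assay on MCF7 cells (Homo sapiens) for antiproliferative activity, read by MTT assay, with a stated time of 48 h (a higher number here means a weaker inhibitor, a lower number a stronger inhibitor), as follows
- compound 1 `Cc1ccc(NCc2cn(-c3ccccc3)nc2-c2ccc(Cl)cc2)cc1` gives 3110 nM
- compound 2 `Clc1ccc(-c2nn(-c3ccccc3)cc2CNc2ccc(Br)cc2)cc1` gives 2620 nM

Among the compounds with values here, these are the only two numbers so far, and they lie within the scatter of each other, so compound 1 stands level with compound 2. Next is the unmeasured compound 3 `Cc1ccc(NCc2cn(-c3ccccc3)nc2-c2ccc(Br)cc2)cc1`. Its difference from compound 1 is bromo in place of chloro on an aromatic carbon, turning 4-chlorophenyl into 4-bromophenyl. Within the data shown here, only one measured step bears on this, and only indirectly: a 1.2-fold lower number from compound 1 to compound 2 (0.07 log units; within the scatter) puts bromo in place of methyl, a different exchange, and stays within the scatter. Among the measured compounds shown here, no measured step covers chloro to bromo itself. No shift beyond the scatter is therefore expected in this assay. The expected step is a 1.1-fold lower number from compound 1 to compound 3 (0.03 log units; within the scatter). For compound 3 the estimated value is 2900 nM, with an expected range from 1500 nM to 5800 nM.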

Compound 3, half-maximal inhibitory concentration: 5380 nM
Compound 3: middle estimate off by 1.9-fold (0.27 log units), on the low side, within the range that was stated.
By their numbers in this assay, from the lowest: compounds 2, 1 and 3 (each within the scatter of the next, the first and the last beyond it).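

Within the data shown here, the exchange of 4-chlorophenyl for 4-bromophenyl gives a 1.7-fold higher number from compound 1 to compound 3 (0.24 log units; within the scatter) in this assay and is the first reading at this position, the earlier step having concerned a different place on the shared core. Bromo therefore takes the place of chloro here without a shift beyond the scatter, although this single exchange between two halogens cannot define the position as a whole. Nothing at hand bears on why the step has this size.

On these data alone, whether a quite different group at this position, such as an amine, a methoxy group or a carboxylic acid, would move the number beyond the scatter remains open. Also open, as far as these compounds go, is whether removing the halogen altogether, leaving an unsubstituted phenyl, would change the number in this assay at all.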